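Ethyl in place of chloro: expectation for compound 3

This account rests on a few compounds, and the source may have more. Where it says the series, first, only, none or still open, it means among the compounds named here.

Measured so far:
compound 1 `CCc1cc(C)cc2nc(N3CCN(C)CC3)oc12` gives 6.46
compound 2 `CN1CCN(c2nc3cc(Cl)cc(Cl)c3o2)CC1` gives 6.51

For the measured compounds named here, in a functional assay on ileum (strain Hartley) for agonist activity at 5-hydroxytryptamine receptor 3A (Cavia porcellus) (a lower number here means a less potent compound, a higher number a more potent compound, by a factor of ten per unit of this negative logarithm), compound 2 gives 6.51, the higher of the two numbers so far; compound 1 gives 6.46, and the two lie within the scatter of each other, so no order between them can be read.

Compound 3 `CCc1cc(Cl)cc2nc(N3CCN(C)CC3)oc12` differs from compound 2 in one place: ethyl in place of chloro on an aromatic carbon. Compound 1 carries the same ethyl at that place, together with a methyl where compound 3 keeps the chloro of compound 2, and its value matches that of compound 2 within the scatter. Going by the values given here, no step between measured compounds is known for this change. The expectation is therefore a step from compound 2 to compound 3 of a number 0.01 log units lower from compound 2 to compound 3 (within the scatter), in no direction beyond the scatter.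

For compound 3 the estimate is 6.5, with a range from 6 to 7.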

Compound 3, negative logarithm of the half-maximal effective concentration: 6.82
Estimate against measurement, compound 3: 0.32 log units below; measured number inside the range.
By their numbers in this assay, from the lowest: compounds 1 and 2 (each within the scatter of the next); then compound 3.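

In this assay, ethyl in place of chloro on the aromatic carbon ortho to a fused ring gives a number 0.31 log units higher from compound 2 to compound 3 (beyond the scatter), showing that this position is sensitive to the change when the second chloro group is kept. With the ethyl group kept, chloro in place of methyl on an aromatic carbon gives a number 0.36 log units higher from compound 1 to compound 3 (beyond the scatter), so the close match of compound 1 and compound 2, which differ in two places, did not mean that either place was indifferent. Nothing available accounts for either step.

Each place rests on a single step, so no trend in group size or type can be drawn. Going by these compounds, whether a longer chain such as propyl, or an amine, would hold or extend the higher number at the ethyl position remains open.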